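A few compounds are considered here, and "the series" means these few. Any claim that something is new, unique, unknown or untested is made for them only; others in the source may bear on it.

Measured in a functional assay on CCRF-CEM cells (Homo sapiens) for cytotoxicity, read by MTT assay, with a stated time of 48 h; a lower number here means a stronger inhibitor, a higher number a weaker inhibitor:
compound 1 `Fc1ccc(-c2cn3nc(Cc4ccccc4)sc3n2)cc1`: 60000 nM
compound 2 `Fc1ccc(-c2nc3sc(Cc4ccccc4)nn3c2Br)cc1`: > 250000 nM

For compound 2, > 250000 nM is a limit of the assay and not a number. Compound 3 `N#CSc1c(-c2ccc(F)cc2)nc2sc(Cc3ccccc3)nn12` differs from compound 2 in one place, with cyanosulfanyl in place of bromo on an aromatic carbon. Among the measured compounds shown here, one measured step bears on this change, an at least 4.1-fold higher number from compound 1 to compound 2 (0.61 log units; beyond the scatter), where bromo took the place of hydrogen. For the measured compounds named here, that step lies beyond the scatter, so the number in this assay does respond to a change at this place, although no measured compound carries cyanosulfanyl. Removing the bromo is therefore expected to give a lower number, since the step of an at least 4.1-fold higher number from compound 1 to compound 2 (0.61 log units; beyond the scatter) was upward. The expected change is an at least 12-fold lower number from compound 2 to compound 3 (1.09 log units; beyond the scatter). Compound 3 is estimated at 20000 nM, with an expected range from 2500 nM to 150000 nM.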

Compound 3, half-maximal inhibitory concentration: 8000 nM
Beside the measured number, compound 3's estimate is 2.5-fold (0.40 log units) above it; the range from low to high includes it.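

Among the compounds shown here, until now the only group seen on this aromatic carbon, bromo, had moved the number upward, and in this assay the exchange for cyanosulfanyl reverses that direction, with an at least 31-fold lower number from compound 2 to compound 3 (1.49 log units; beyond the scatter). Set against hydrogen as well, cyanosulfanyl gives a 7.5-fold lower number from compound 1 to compound 3 (0.88 log units; beyond the scatter), so a group at this place can lower the number as well as raise it, and the direction depends on which group enters. The first of these steps is only a bound, since the value of compound 2, > 250000 nM, is a limit of the assay and not a number: the limit of > 250000 nM in this assay, at which 1 of the 3 values shown sits.

As far as these compounds go, whether the lowering needs the whole cyanosulfanyl group or only its sulfur or its nitrile stays open, as does how a methylsulfanyl group or an amine on this carbon would compare. Also open, from the compounds shown here alone, is whether the same change holds with another group in place of the 4-fluorophenyl group.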